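This account rests on a few compounds, and the source may have more. Where it says the series, first, only, none or still open, it means among the compounds named here.

Measured compounds:
- Compound 1, `C#CC[C@H]1C[C@H](n2cccc2)C(=O)O1`, gives > 100000 nM in an ADME assay on N2a cells (Mus musculus) for cytotoxicity, read by MTT assay; on this read-out higher numbers stand for weaker inhibition and lower numbers for stronger inhibition
- Compound 2, `C#CC[C@@H]1C[C@H](n2cccc2C(=O)CC)C(=O)O1`, gives 40600 nM in this assay

Compound 1 reaches only a limit of the assay in this assay, and that value is a limit rather than a number. Within the data shown here, compound 2 is therefore the one compound with an actual number in this assay, and it stands as the sole measured point from which a comparison can start; the other value shown sits at the limit described in the limit of > 100000 nM in this assay, at which 1 of the 2 values shown sits.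

Compound 3, `C#CC[C@H]1C[C@H](n2cccc2C(=O)CC)C(=O)O1`, has not yet been measured in this assay. Compared with compound 2, the change is the two compounds have the same atoms and bonds and differ only in configuration as drawn: 1 of 2 stereo elements differ; a stereocentre at a saturated ring carbon is drawn R in compound 2 and S in compound 3. The two compounds share every atom and bond; the stereocentre at a saturated ring carbon is drawn R in compound 2 and S in compound 3. Among the measured compounds shown here, no pair of measured compounds in this set shows what such a change does in this assay, so the expected step rests on the structural change alone.

For a cytotoxicity read-out of this kind, a change in configuration at one ring carbon is expected to move the number little, and the step from compound 2 to compound 3 is estimated at a 1.2-fold higher number from compound 2 to compound 3 (0.09 log units; within the scatter), a shift not clearly beyond the scatter. Compound 3 is expected to give about 50000 nM in this assay, within a range of 18000 nM to 140000 nM.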

Compound 3, half-maximal inhibitory concentration: 40700 nM
For compound 3 the middle estimate is 1.2-fold (0.09 log units) above the measured one; measured number inside the range.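

Inverting the stereocentre at a saturated ring carbon in this assay gives a 1.0-fold higher number from compound 2 to compound 3 (0.00 log units; within the scatter), so for this pair the drawn configuration at that carbon leaves the cytotoxicity read-out unmoved, and the comparison is a clean one: the fact that compounds 2 and 3 differ only in the configuration as drawn. Compound 1 gives > 100000 nM, which is a limit of the assay and not a number. Among these compounds, with the configuration now matched, propanoyl in place of hydrogen on an aromatic carbon gives an at least 2.4-fold lower number from compound 1 to compound 3 (0.39 log units; beyond the scatter), the first step in this set that can be read as beyond the scatter, although its full size remains unknown: the limit of > 100000 nM in this assay, at which 1 of the 3 values shown sits.

Going by these compounds, it remains open whether a longer chain such as butanoyl, or an amine or a carboxylic acid in place of propanoyl, would shift the number further in either direction. On these data alone, it is also open whether the second stereocentre matters, since these compounds test a change at only one of the two, and whether the lack of a difference between the two forms would persist with a different group on the aromatic carbon.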